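Cytotoxicity notes: shortening the phenyl alkyl chain

The source may hold more compounds than are shown below. What is called first, only, known or untested is meant among the compounds shown, and "the series" means these compounds.

Measured so far:
Compound 1 `Cc1ccc(-c2ccc3ncc(-c4noc(C(F)(F)F)n4)cc3c2)cc1` in a functional assay on RD cells (Homo sapiens) for inhibition, read by luminescence and ATP content, with a stated time of 72 h (a lower number here means that less compound is tolerated, a higher number that more compound is tolerated), gives > 22200 nM, which is a limit of the assay.
Compound 2 `CCCc1ccc(-c2ccc3ncc(-c4noc(CC)n4)cc3c2)cc1` in this assay gives > 7400 nM, also a limit of the assay.

Compound 2 thus stands at a limit of > 7400 nM in this assay, at which 1 of the 2 values shown sits, and cannot be placed above or below compound 1, whose value is likewise a limit (the limit of > 22200 nM in this assay, at which 1 of the 2 values shown sits). Neither compound shows a measurable half-maximal cytotoxic concentration within its tested range.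

Compound 3 `CCc1nc(-c2cnc3ccc(-c4ccc(C)cc4)cc3c2)no1` differs from compound 2 by hydrogen in place of ethyl on a saturated chain carbon bound to an aromatic carbon; cut one bond further out, the same difference reads propyl to methyl. Going by the values given here, no step between measured compounds covers this change. With both known values being limits, the expected step that the limit leaves unreadable from compound 2 to compound 3 in this assay is none beyond the usual scatter, and the outcome is most likely again only a limit. Compound 3 is expected at 30000 nM, within 8000 nM to 100000 nM.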

Compound 3, half-maximal cytotoxic concentration: > 7400 nM
Compound 3 ended at the assay's limit; the forecaster's own chance of this, stated with the estimate: 85%; the middle value lies beyond the limit too.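

Compound 1, compound 2 and compound 3 all stand at limits, so no step among them can be read in this assay: the limit of > 7400 nM in this assay, at which 2 of the 3 values shown sit.

Still open, from the compounds shown here alone, is whether hydrogen in place of ethyl, or ethyl in place of trifluoromethyl, shifts the half-maximal cytotoxic concentration at all.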